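This account rests on a few compounds, and the source may have more. Where it says the series, first, only, none or still open, it means among the compounds named here.

Measured compounds:
- compound 1 `C=CCn1c(=O)/c(=C\c2ccccc2Cl)[nH]c(=O)/c1=C\c1ccccc1OC`: 700 nM
- compound 2 `C=CCn1c(=O)/c(=C\c2ccc(C)cc2)[nH]c(=O)/c1=C\c1ccccc1OC`: "not active" (no number reported)
- compound 3 `C=CCn1c(=O)/c(=C\c2cccc(C)c2)[nH]c(=O)/c1=C\c1ccccc1OC`: 5100 nM

In a functional assay on U-937 cells (Homo sapiens) for cytotoxicity, read by CCK-8 assay, with a stated time of 72 h (a lower number here means a stronger inhibitor, a higher number a weaker inhibitor), compound 3 gives the highest of the two reported numbers; its nearest neighbour is compound 1, a lower number, with the step of a 7.3-fold higher number from compound 1 to compound 3 (0.86 log units; beyond the scatter) going the other way. For compound 2 no number was reported in this assay.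

Compound 4 `C=CCn1c(=O)/c(=C\c2ccccc2F)[nH]c(=O)/c1=C\c1ccccc1OC` differs from compound 3 by 2-fluorophenyl in place of 3-methylphenyl on a double-bonded chain carbon bound to an aromatic carbon. For the measured compounds named here, only one step bears on this: from compound 1 to compound 3, a 7.3-fold higher number from compound 1 to compound 3 (0.86 log units; beyond the scatter), where a 2-chlorophenyl gave way to a 3-methylphenyl. Compound 4 brings a halogen back in the same place, so a downward step a 4.3-fold lower number from compound 3 to compound 4 (0.63 log units; beyond the scatter) of similar size is expected. Compound 4 is estimated at 1200 nM, within 400 nM to 4000 nM.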

Compound 4, half-maximal inhibitory concentration: 5500 nM
Compound 4: middle estimate off by 4.6-fold (0.66 log units), on the low side; measured number above the stated range.
By their numbers in this assay, from the lowest: compound 1; then compounds 3 and 4 (each within the scatter of the next).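

In this assay, fluoro in place of chloro on an aromatic carbon is a real loss, a 7.9-fold higher number from compound 1 to compound 4 (0.90 log units; beyond the scatter), so a halogen alone does not bring the lower number of compound 1. The 2-fluorophenyl and 3-methylphenyl groups cannot be told apart here, a 1.1-fold higher number from compound 3 to compound 4 (0.03 log units; within the scatter), which leaves compound 1 alone with the lowest number of the three. No measurement on hand explains why chloro and fluoro differ. Still open, as far as these compounds go, is whether bromo or methoxy in place of chloro on that aromatic carbon would hold the number of compound 1.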